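A biaryl swap on a bile acid receptor ligand

A few compounds are considered here, and "the series" means these few. Any claim that something is new, unique, unknown or untested is made for them only; others in the source may bear on it.

Three compounds share one core and differ only in the group on one aromatic carbon. Compound 1 `COC(=O)/C=C/c1cccc(N(Cc2ccc(/C=C/c3ccccc3F)cc2)C(=O)NC(C)C)c1` gives 431 nM in an assay on isolated protein with Bile acid receptor (Homo sapiens) as the target; on this read-out lower numbers stand for an effect already at smaller amounts and higher numbers for an effect only at larger amounts of compound. Compound 2 `COC(=O)/C=C/c1cccc(N(Cc2ccc(-c3cccc(OC)c3)cc2)C(=O)NC(C)C)c1` gives 1370 nM, and compound 3 `COC(=O)/C=C/c1cccc(N(Cc2ccc(/C=C/C(=O)OC(C)(C)C)cc2)C(=O)NC(C)C)c1` gives 212 nM, the lowest of the three numbers. The steps are modest but beyond the scatter: a 2.0-fold lower number from compound 1 to compound 3 (0.31 log units; beyond the scatter), a 3.2-fold higher number from compound 1 to compound 2 (0.50 log units; beyond the scatter) and a 6.5-fold lower number from compound 2 to compound 3 (0.81 log units; beyond the scatter).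

Compound 4 `COC(=O)/C=C/c1cccc(N(Cc2ccc(-c3c(OC)cccc3OC)cc2)C(=O)NC(C)C)c1` is not yet measured. Its change from compound 3 is 2,6-dimethoxyphenyl in place of 2-(tert-butoxycarbonyl)ethenyl on an aromatic carbon. Among the measured compounds shown here, the most relevant measured step is the one from compound 2 to compound 3, where a methoxyphenyl gave the higher number and the ester-bearing chain the lower one; compound 4 reverses that move toward a methoxy-bearing phenyl, though with a different pattern of two methoxy groups, for which no measured comparison exists. A step back toward the number of compound 2 is therefore expected, in the direction of a higher number, estimated as a 5.7-fold higher number from compound 3 to compound 4 (0.75 log units; beyond the scatter). Compound 4 is expected to give about 1200 nM, within a range from 400 nM to 4000 nM.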

Compound 4, half-maximal effective concentration: 561 nM
Beside the measured number, compound 4's estimate is 2.1-fold (0.33 log units) above it; the range from low to high includes it.
By their numbers in this assay, from the lowest: compound 3; then compounds 1 and 4 (each within the scatter of the next); then compound 2.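

This position accepts a directly attached phenyl ring with methoxy groups without the number rising to that of compound 2: 2,6-dimethoxyphenyl in place of 3-methoxyphenyl gives a clear change (a 2.4-fold lower number from compound 2 to compound 4 (0.39 log units; beyond the scatter)), so the pattern of methoxy groups on that ring matters, not just the presence of the ring. The two ethenyl chains now separate, since the 2-(tert-butoxycarbonyl)ethenyl group of compound 3 keeps its lead (a 2.6-fold higher number from compound 3 to compound 4 (0.42 log units; beyond the scatter)), whereas the 2-(2-fluorophenyl)ethenyl group of compound 1 cannot be told apart from the 2,6-dimethoxyphenyl group (a 1.3-fold higher number from compound 1 to compound 4 (0.11 log units; within the scatter)). No evidence at hand explains these differences.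

Going by these compounds, whether a carboxylic acid in place of the tert-butyl ester, or an amine on the phenyl ring, would come closer to compound 3 or to compound 2 remains open. So does the question of which of the two methoxy groups in compound 4 accounts for its step from compound 2.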